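The source may hold more compounds than are shown below. What is called first, only, known or untested is meant among the compounds shown, and "the series" means these compounds.

Compound 1 `O=C(NC1CCCCC1)Oc1cccc(-n2ccc(C(=O)OCCCCCCc3ccccc3)c2)c1`, compound 2 `NC(=O)c1ccn(-c2cccc(OC(=O)NCCOCCOc3ccccc3)c2)c1`, compound 3 `NC(=O)c1ccn(-c2cccc(OC(=O)NCCOCCOc3ccccc3F)c2)c1`.

In an assay (brain) for inhibition of Fatty-acid amide hydrolase 1 (Mus musculus), with stated times of 20 min and 15 min (a higher number here means a weaker inhibitor, a lower number a stronger inhibitor), compound 1 gives only a limit, > 50000 nM. In this assay compound 2 gives 87 nM. In this assay compound 3 gives 69 nM. Compound 3 thus stands next to compound 2, since the step of a 1.3-fold lower number from compound 2 to compound 3 (0.10 log units; within the scatter) is within the scatter, while compound 1 sits at a limit.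

Compound 4 `NC(=O)c1ccn(-c2cccc(OC(=O)NCCOCCOc3c(F)cc(F)cc3F)c2)c1` differs from compound 3 by 2,4,6-trifluorophenyl in place of 2-fluorophenyl on an oxygen on a saturated carbon. Among the compounds with values here, the only measured step bearing on this change is a 1.3-fold lower number from compound 2 to compound 3 (0.10 log units; within the scatter), a single fluorine on the same ring that left the number within the scatter. Two further fluorines on that ring are therefore expected to move the number little in this assay. The estimate for compound 4 is 60 nM, expected to fall between 25 nM and 150 nM. The expected step of a 1.2-fold lower number from compound 3 to compound 4 (0.06 log units; within the scatter) is within the scatter.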

Compound 4, half-maximal inhibitory concentration: 43 nM
For compound 4 the middle estimate is 1.4-fold (0.14 log units) above the measured one; the measured number falls inside the stated range.
By their numbers in this assay, from the lowest: compounds 4, 3 and 2 (each within the scatter of the next, the first and the last beyond it). At a limit, above all of these: compound 1.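

At this position, on an oxygen on a saturated carbon, the ring carries three fluorines and the number in this assay stays within the scatter of the single-fluorine compound, with a 1.6-fold lower number from compound 3 to compound 4 (0.21 log units; within the scatter) for the change from 2-fluorophenyl to 2,4,6-trifluorophenyl. Measured from the plain phenyl, however, the same ring gives a 2.0-fold lower number from compound 2 to compound 4 (0.31 log units; beyond the scatter) as a modest step, the first on this ring to pass the scatter.

On these data alone, whether a trifluoromethyl or methoxy group on this ring, or a longer chain carrying it, would hold the number stays open. Nothing measured among the compounds shown accounts for these steps.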